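A few compounds are considered here, and "the series" means these few. Any claim that something is new, unique, unknown or untested is made for them only; others in the source may bear on it.

In a functional assay on the whole organism (strain Hart Swiss) with Mus musculus as the target, with stated times of 5 days and 2 weeks, at a dose of 20 mg/kg by the intraperitoneal route (a lower number here means a weaker effect, a higher number a stronger effect of the compound at the dose given), compound 1 `CCOC(=O)/C=C(C)/C(F)=C/C=C(C)/C=C/c1c(C)cc(OC)c(C)c1C` gives 62% and compound 2 `CCNC(=O)/C=C(C)/C(F)=C/C=C(C)/C=C/c1c(C)cc(OC)c(C)c1C` gives 67%. Among the compounds with values here, the one measured step, a number 5 percentage points higher from compound 1 to compound 2 (within the scatter), lies within the scatter. Compound 2 thus stands highest of the two numbers shown, but compound 1 sits within the scatter of it, so no order between the two can be read. Compound 3 `CCNC(=O)/C=C(C)/C=C/C=C(C)/C=C/c1c(C)cc(OC)c(C)c1C` differs from compound 2 in one place: hydrogen in place of fluoro on a double-bonded chain carbon bound to two double-bonded chain carbons. Within the data shown here, no measured step touches this place; the only step known, a number 5 percentage points higher from compound 1 to compound 2 (within the scatter), concerns the carbonyl carbon and says nothing about the fluoro. The expectation for this assay therefore rests on compound 2 alone, with wide uncertainty, and no step beyond the scatter is expected in either direction: the estimated step is a number 7 percentage points lower from compound 2 to compound 3 (within the scatter). Compound 3 is expected to give 60%, in the range 35% to 85%.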

Compound 3, a percentage reported as activity, at one dose (the size of the read-out at that dose, not a potency): 54%
For compound 3 the middle estimate is 6 percentage points above the measured one, and the stated range covers the measured number.
By their numbers in this assay, from the lowest: compounds 3, 1 and 2 (each within the scatter of the next, the first and the last beyond it).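

In this assay, within the data shown here, hydrogen in place of fluoro on a double-bonded chain carbon bound to two double-bonded chain carbons gives a number 13 percentage points lower from compound 2 to compound 3 (beyond the scatter), a modest change and the first step beyond the scatter. The earlier step at the carbonyl carbon, a number 5 percentage points higher from compound 1 to compound 2 (within the scatter), did not show that a change in the series could register at this dose, whereas this chain position now does, on the evidence of this single pair. Nothing available explains the loss seen with hydrogen at this place.

On these data alone, it remains open whether chloro, methyl or trifluoromethyl at this chain carbon would match fluoro or hydrogen in this assay. Also open, as far as these compounds go, is whether the fluoro step would keep its size with ethoxy or a carboxylic acid on the carbonyl carbon.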